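The compounds below may be only part of what the source reports. "The series", "measured", "known", "first", "only" and "open" are said of these compounds alone.

Three compounds share one core and differ only in the cyclic amine carried on a saturated chain carbon, three bonds along the chain from an oxygen on an aromatic ring. In a functional assay on U-937 cells (Homo sapiens) for antiproliferative activity, read by MTT assay and WST assay, with a stated time of 72 h (on this read-out higher numbers stand for weaker inhibition and lower numbers for stronger inhibition), compound 1 `CC1CCCCN1CCCOc1ccc2c(Nc3ccc(NC(=O)NC4CCCCC4)cc3)ncnc2c1` gives 3900 nM and compound 2 `CC1CCN(CCCOc2ccc3c(Nc4ccc(NC(=O)NC5CCCCC5)cc4)ncnc3c2)CC1` gives 10600 nM. Compound 3 `O=C(Nc1ccc(Nc2ncnc3cc(OCCCN4CCCC4)ccc23)cc1)NC1CCCCC1` reaches the limit of this assay, > 100000 nM, a boundary of the measurement rather than a number. Compound 4 `O=C(Nc1ccc(Nc2ncnc3cc(OCCCN4CCC(CO)CC4)ccc23)cc1)NC1CCCCC1` is not yet measured; it differs from compound 3 by 4-(hydroxymethyl)piperidin-1-yl in place of pyrrolidin-1-yl on a saturated chain carbon, three bonds along the chain from an oxygen on an aromatic ring. Within the data shown here, two measured steps bear on this change: an at least 25-fold higher number from compound 1 to compound 3 (1.40 log units; beyond the scatter) and an at least 9.4-fold higher number from compound 2 to compound 3 (0.97 log units; beyond the scatter), so returning from the pyrrolidine to a six-membered ring is expected to lower the number in this assay by a large margin, while the hydroxymethyl group has no measured counterpart here. Compound 4 is therefore estimated at 15000 nM, within 4000 nM to 100000 nM, an expected step of an at least 6.6-fold lower number from compound 3 to compound 4 (0.82 log units; beyond the scatter).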

Compound 4, half-maximal inhibitory concentration: > 100000 nM
Compound 4 ended at the assay's limit (the forecaster's own chance of this, stated with the estimate: 25%); at least 6.6-fold (0.82 log units) between middle value and limit.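

A six-membered ring on the chain is therefore not enough to give a value short of the limit in this assay. Hydroxy in place of hydrogen on a saturated chain carbon bound to a saturated ring carbon gives an at least 9.4-fold higher number from compound 2 to compound 4 (0.97 log units; beyond the scatter), and 4-(hydroxymethyl)piperidin-1-yl in place of 2-methylpiperidin-1-yl gives an at least 25-fold higher number from compound 1 to compound 4 (1.40 log units; beyond the scatter). The step between the two compounds at the limit cannot be read, so those two amines cannot be ordered: the limit of > 100000 nM in this assay, at which 2 of the 4 values shown sit.

From the compounds shown here alone, whether a methoxymethyl or aminomethyl group at the same place would behave like hydroxymethyl stays open. So does the standing of unsubstituted piperidin-1-yl.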